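Methylsulfanyl to carboxy at the aromatic ring

A few compounds are considered here, and "the series" means these few. Any claim that something is new, unique, unknown or untested is made for them only; others in the source may bear on it.

The series shares an oxazolidinone amide core with a chain to a substituted aromatic ring, measured in an assay on HEK293 cells for inhibition of N-acylethanolamine-hydrolyzing acid amidase (Rattus norvegicus), read by LC-MS, with a stated time of 30 min; a higher number here means a weaker inhibitor, a lower number a stronger inhibitor. Compound 1 `O=C(CCCCCc1ccc(F)c(Cl)c1)N1CCOC1=O` gives 26 nM in this assay. Compound 3 `O=C(CCCCCc1ccc(O)c(F)c1)N1CCOC1=O` gives 160 nM. Compound 2 `CSc1cccc(CCCCCC(=O)N2CCOC2=O)c1` gives 12800 nM, the highest of the three numbers; its gaps to compound 3 and to compound 1 both lie beyond the scatter, so compound 2 is the weakest inhibitor shown.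

Compound 4 `O=C(O)c1cccc(CCCCCC(=O)N2CCOC2=O)c1` differs from compound 2 in one place: carboxy in place of methylsulfanyl on an aromatic carbon. Among the compounds with values here, no measured pair in the set isolates such a change, so the expectation rests on compound 2 alone, which already sits at 12800 nM. The step from compound 2 to compound 4 in this assay is expected to be small, in the direction of a weaker inhibitor or none beyond the scatter, giving a 1.6-fold higher number from compound 2 to compound 4 (0.19 log units; within the scatter). Compound 4 is therefore estimated at 20000 nM, with a range from 5000 nM to 80000 nM.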

Compound 4, half-maximal inhibitory concentration: > 20000 nM
Compound 4: no number, only a limit; the forecaster's own chance of this, stated with the estimate: 25%; the middle value sits exactly at the limit.
By their numbers in this assay, from the lowest: compound 1; then compound 3; then compound 2. At a limit, above all of these: compound 4.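

In this assay compound 4 gives > 20000 nM, which is a limit of the assay and not a number. On this aromatic carbon, meta to a large group, carboxy in place of methylsulfanyl brings no drop in the number: the change gives an at least 1.5-fold higher number from compound 2 to compound 4 (0.19 log units; that floor lies within the scatter), so only a floor is known for the step and its true size stays unread. Carboxy adds a hydrogen-bond donor that methylsulfanyl lacks, yet no lower number appears at this position, and the reading for this change rests on a single entry: the limit of > 20000 nM in this assay, at which 1 of the 4 values shown sits.

The compounds shown leave open whether a methyl ester or an amine on this same aromatic carbon would give a lower number than either group tested here. They also leave open whether a shorter chain would alter the effect of this change.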